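Swapping an Amino Group for Methyl on a Fused Core

A few compounds are considered here, and "the series" means these few. Any claim that something is new, unique, unknown or untested is made for them only; others in the source may bear on it.

Three compounds from one series have been characterised in a physicochemical assay for acid dissociation. Compound 1 `Cc1nc2c(OCc3ccccc3)cccn2c1C` gives 7, and compound 2 `Cc1nc2c(OCc3ccccc3)cccn2c1N` gives 6.81 in this assay. These two differ in a single place: methyl in place of amino on an aromatic carbon. That exchange produced a number 0.19 log units higher from compound 2 to compound 1 (within the scatter), a step that lies within the usual scatter of the measurement, so the two numbers cannot be told apart. Compound 3 `Cc1nc2c(OCc3ccccc3)nccn2c1N` is built on a different core, and in this assay compound 3 gives 4.6, the lowest of the three numbers, lying beyond the scatter from both compound 2 and compound 1. The difference between the two cores is not broken down here.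

Compound 4 `Cc1nc2c(OCc3ccccc3)nccn2c1C` has not yet been measured. It stands to compound 3 as compound 1 stands to compound 2: methyl in place of amino on an aromatic carbon. The place of the change reads the same in both pairs, so this is the same change carried onto another core. Because the earlier exchange produced a number 0.19 log units higher from compound 2 to compound 1 (within the scatter), a step within the scatter, the expectation is that the same exchange on the core of compound 3 also moves the number little. The change is expected to produce a number 0.20 log units higher from compound 3 to compound 4 (within the scatter). Compound 4 is therefore estimated to give 4.8 in this assay, most likely between 4.2 and 5.4. Among the compounds with values here, the range is kept wide, as only one measured pair carries this change.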

Compound 4, acid dissociation constant: 4.8
The estimate for compound 4 equals the measured number at the digits printed; measured number inside the range.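

In this assay, the exchange of amino for methyl on an aromatic carbon gives a number 0.20 log units higher from compound 3 to compound 4 (within the scatter), and on the core of compound 2 the same exchange gives a number 0.19 log units higher from compound 2 to compound 1 (within the scatter), so in both pairs the two compounds cannot be told apart. Within this series, then, the exchange carries from one core to the other without a step that can be read, but two pairs are a small base, and neither shows that the exchange would leave the number unmoved on every core, nor can steps this small show whether the two cores truly respond alike. Nothing available explains why the exchange leaves so little mark on either core.

The compounds shown leave open how other groups on the same aromatic carbon would read in this assay, for example ethyl, a longer chain such as butyl, or a carboxylic acid, any of which could give a step beyond the scatter or stay within it. They also leave open whether the exchange of amino for methyl would stay this small on a third core.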